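A few compounds are considered here, and "the series" means these few. Any claim that something is new, unique, unknown or untested is made for them only; others in the source may bear on it.

Working notes on the series. Three compounds have numbers in a functional assay on SN12C cells (Homo sapiens) for inhibition, read by sulforhodamine B assay, with a stated time of 48 h; on this read-out higher numbers stand for weaker inhibition of growth and lower numbers for stronger inhibition of growth. Compound 1 `O=C(Nc1cccc(-n2cc(-c3ccncc3)c(-c3ccc(Cl)c(O)c3)n2)c1)Nc1cccc(C(F)(F)F)c1` carries a hydroxy on one ring and a 3-(trifluoromethyl)phenyl urea; in this assay compound 1 gives 2010 nM. Compound 2 `COc1cc(-c2nn(-c3cccc(NC(=O)c4cccc(C(F)(F)F)c4)c3)cc2-c2ccncc2)ccc1Cl` carries a methoxy and a 3-(trifluoromethyl)phenyl amide; in this assay compound 2 gives 3310 nM. Compound 3 `COc1cc(-c2nn(-c3cccc(NC(=O)Nc4ccc(Cl)c(Cl)c4)c3)cc2-c2ccncc2)ccc1Cl` keeps the methoxy and carries a (3,4-dichlorophenyl) urea; in this assay compound 3 gives 1470 nM. Among the compounds with values here, the one single-point step measured so far is a 2.3-fold lower number from compound 2 to compound 3 (0.35 log units; beyond the scatter). Compound 3 stands at the lowest of the three numbers, but its gap to compound 1 is within the scatter, so no order between those two is claimed; only the gap to compound 2 is beyond it.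

Compound 4 `O=C(Nc1cccc(-n2cc(-c3ccncc3)c(-c3ccc(Cl)c(O)c3)n2)c1)Nc1ccc(Cl)c(Cl)c1` is compound 3 with hydrogen in place of methyl on an oxygen on an aromatic ring. Within the data shown here, no measured step covers this change: compound 1 and compound 3 differ at the oxygen and at the urea aryl together, and their two values lie within the scatter of each other. On that basis no step beyond the scatter is expected, and the estimate of a 1.0-fold higher number from compound 3 to compound 4 (0.01 log units; within the scatter) is centred close to compound 3. Compound 4 is therefore expected to give about 1500 nM in this assay, within a range of 650 nM to 3400 nM.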

Compound 4, concentration for 50% growth inhibition: 1310 nM
For compound 4 the middle estimate is 1.1-fold (0.06 log units) above the measured one; the measured number falls inside the stated range.
By their numbers in this assay, from the lowest: compounds 4, 3, 1 and 2 (each within the scatter of the next, the first and the last beyond it).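

In this assay, the change from 4-chloro-3-methoxyphenyl to 4-chloro-3-hydroxyphenyl now has a direct reading with the 3,4-dichlorophenyl urea held constant: a 1.1-fold lower number from compound 3 to compound 4 (0.05 log units; within the scatter), so with this urea, methyl and hydrogen on that oxygen on an aromatic ring are not told apart by this read-out. The urea aryl also has its first reading with the hydroxy held constant: a 1.5-fold lower number from compound 1 to compound 4 (0.19 log units; within the scatter), so 3,4-dichlorophenyl and 3-(trifluoromethyl)phenyl on the amide-type nitrogen are not told apart here either. Within the data shown here, the only step beyond the scatter remains a 2.3-fold lower number from compound 2 to compound 3 (0.35 log units; beyond the scatter), and neither new step adds a second one.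

From the compounds shown here alone, the reading at the oxygen rests on a single pair, so it remains open whether it holds with the 3-(trifluoromethyl)phenyl urea or the 3-(trifluoromethyl)phenyl amide. Going by these compounds, it also remains open whether the same flat reading would extend to an ethoxy group, a longer alkoxy chain, or an amine in place of the hydroxy. Nothing at hand bears on why the methoxy and hydroxy compounds read alike in this assay.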